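A Thiazole in Place of a Pyridine on the Sulfonamide

A few compounds are considered here, and "the series" means these few. Any claim that something is new, unique, unknown or untested is made for them only; others in the source may bear on it.

Of the compounds shown here, three have been measured in a functional assay on SK-OV-3 cells (Homo sapiens) for antiproliferative activity, read by sulforhodamine B assay, with a stated time of 72 h; a lower number here means a stronger inhibitor, a higher number a weaker inhibitor. Compound 1 `Cc1ccc(C(/C=C/c2ccc(F)cc2)=N\Nc2nncc3ccccc23)cc1` gives 0.07 nM in this assay, and compound 2 `Clc1ccc(C(/C=C/c2ccccc2)=N\Nc2nncc3ccccc23)cc1` gives 0.07 nM. Compound 3 `O=S(=O)(Nc1ccccn1)c1ccc(Nc2nncc3ccccc23)cc1`, whose sulfonamide carries a pyridin-2-yl group, gives 0.9 nM, which is the highest of the three numbers; both compound 1 and compound 2 lie at lower numbers, and the gaps to each of them are beyond the usual scatter. Compound 3 is thus the weakest inhibitor among the measured compounds.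

Compound 4 `O=S(=O)(Nc1nccs1)c1ccc(Nc2nncc3ccccc23)cc1` has not yet been measured. It differs from compound 3 in one place: 1,3-thiazol-2-yl in place of pyridin-2-yl on a sulfonamide nitrogen. The rest of the molecule, including the shared core and the sulfonamide linkage, is unchanged. Going by the values given here, no measured pair shows this exchange, so there is no step to lean on. Given that compound 3 stands at 0.9 nM, the change is expected to produce no step beyond the scatter in this assay, that is a step of about a 1.1-fold higher number from compound 3 to compound 4 (0.05 log units; within the scatter). Compound 4 is therefore estimated at 1 nM, with a range from 0.3 nM to 3.5 nM.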

Compound 4, half-maximal inhibitory concentration: 7.7 nM
Beside the measured number, compound 4's estimate is 7.7-fold (0.89 log units) below it, outside the stated range (above it).
By their numbers in this assay, from the lowest: compounds 1 and 2 (each within the scatter of the next); then compound 3; then compound 4.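

Going by these compounds alone, the exchange of pyridin-2-yl for 1,3-thiazol-2-yl on a sulfonamide nitrogen gives the first step that can be read in this assay, namely an 8.6-fold higher number from compound 3 to compound 4 (0.93 log units; beyond the scatter), and it shows that this position is sensitive to the group it carries. With the shared core and the sulfonamide linkage unchanged, replacing one aromatic ring with another is enough to move the number beyond the scatter, and of these two groups, pyridin-2-yl gives the stronger inhibitor. Nothing at hand bears on what lies behind this step, and the two rings differ in several counted features that this single pair cannot separate.

The compounds shown leave open where a plain phenyl, a pyrimidin-2-yl or a 1,3-thiazol-2-yl carrying a methyl group on this nitrogen would fall relative to compound 3 and compound 4. They also leave open whether the sulfonamide nitrogen needs an aromatic ring at all, or whether a small alkyl group such as methyl, or the unsubstituted sulfonamide, would serve in its place.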